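Ester for chloro on the tetrazole aryl group

A few compounds are considered here, and "the series" means these few. Any claim that something is new, unique, unknown or untested is made for them only; others in the source may bear on it.

Compound 2 `CC(Oc1ccc(Oc2ccc(F)cc2)cc1)C(=O)Cn1nnc(-c2ccc(Cl)cc2)n1` stands at a limit: in an ADME assay on S9 fraction from liver (Rattus norvegicus) for metabolic stability, read by LC-MS, using NADPH, with a stated time of 30 min (on this read-out higher numbers stand for a more stable compound and lower numbers for a less stable compound), compound 2 gives < 5%, which is a limit of the assay and not a number. Compound 1 `CC(Oc1ccc(Oc2ccc(F)cc2)cc1)C(=O)Cn1nnc(-c2ccccc2)n1` also rests at a limit, giving < 5% in this assay. Compound 3 `CC(Oc1ccc(Oc2ccc(Cl)cc2)cc1)C(=O)Cn1nnc(-c2ccc(Cl)cc2)n1` likewise returns a limit, < 5% in this assay. All three values sit at the limit of < 5% in this assay, at which 3 of the 3 values shown sit. Compound 4 `COC(=O)c1ccc(-c2nnn(CC(=O)C(C)Oc3ccc(Oc4ccc(F)cc4)cc3)n2)cc1` differs from compound 2 by methoxycarbonyl in place of chloro on an aromatic carbon. The two measured steps, a step that the two limits leave unreadable from compound 1 to compound 2 and a step that the two limits leave unreadable from compound 2 to compound 3, each exchange a substituent on an aromatic carbon but yield no readable size, so neither direction nor magnitude can be drawn from them. Compound 4 is therefore expected to remain at the limit, a step that the limit leaves unreadable from compound 2 to compound 4. The estimate for compound 4 is 4%, with a range from 0% to 15%.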

Compound 4, percent of the compound remaining: < 5%
Compound 4 gave a limit, no number (the forecaster's own chance of this, stated with the estimate: 70%); the middle value lies beyond the limit too.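

Within the data shown here, compound 4 rests at a limit, as do compound 1, compound 2 and compound 3, so no step from compound 1 or compound 2 to compound 4 can be read: the limit of < 5% in this assay, at which 4 of the 4 values shown sit. Whether any substituent exchange shown shifts the result in this assay stays open.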